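This account rests on a few compounds, and the source may have more. Where it says the series, first, only, none or still open, it means among the compounds named here.

Compound 1 `COc1cccc(S(=O)(=O)Nc2ccc3oc(-c4ccccc4)nc3c2)c1` gives in an assay on isolated protein for inhibition of malate dehydrogenase, mitochondrial (Sus scrofa), with stated times of 45 min and 30 min (on this read-out higher numbers stand for weaker inhibition and lower numbers for stronger inhibition), the value > 63000 nM, which is a limit of the assay and not a number.
Compound 2 `O=S(=O)(Nc1ccc2oc(-c3ccccc3)nc2c1)c1ccc(Cl)cc1` gives in this assay the value > 63000 nM, again a limit of the assay.
Compound 3 `O=S(=O)(Nc1ccc2oc(-c3ccccc3)nc2c1)c1ccccc1Cl` gives in this assay the value > 63000 nM, also a limit of the assay.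

Compound 3 therefore stands nowhere in particular among the numbers shown: its result in this assay is a limit, and both other values are limits as well, so none of the three can be placed above or below another. The steps among them, a step that the two limits leave unreadable from compound 1 to compound 2, a step that the two limits leave unreadable from compound 1 to compound 3 and a step that the two limits leave unreadable from compound 2 to compound 3, are all unreadable for the same reason, summed up by the limit of > 63000 nM in this assay, at which 3 of the 3 values shown sit.

The step to compound 4 `O=S(=O)(Nc1ccc2oc(-c3ccccc3)nc2c1)c1ccc(O)cc1` is 4-hydroxyphenyl in place of 2-chlorophenyl on a sulfonyl sulfur. Going by the values given here, none of the measured steps bears readably on it: every exchange on the sulfonyl sulfur so far has left the value at the limit, so no direction or size can be read out of them. The expectation for compound 4 is therefore that it stays at the limit too, and the step that the limit leaves unreadable from compound 3 to compound 4 is estimated as nothing beyond the scatter. Compound 4 is thus estimated at 100000 nM, with a range from 30000 nM to 400000 nM.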

Compound 4, half-maximal inhibitory concentration: > 63000 nM
Compound 4: a limit, no number; the forecaster's own chance of this, stated with the estimate: 85%; the middle value lies beyond the limit too.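

Compound 4 also returns a limit of the assay and not a number, so no new step can be read from compound 4 to compound 1, compound 2 or compound 3: the limit of > 63000 nM in this assay, at which 4 of the 4 values shown sit. The compounds shown leave open whether any group on the sulfonyl sulfur gives a value in this assay that is not a limit, and how these four compounds rank against one another.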